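From ethyl to hydrogen on a ring nitrogen

The source may hold more compounds than are shown below. What is called first, only, known or untested is meant among the compounds shown, and "the series" means these compounds.

Values in a functional assay on OVCAR-3 cells (Homo sapiens) for antiproliferative activity, read by sulforhodamine B assay, with a stated time of 72 h; on this read-out lower numbers stand for stronger inhibition and higher numbers for weaker inhibition:
- compound 1 `O=C1CS/C(=N/Nc2nncc3ccccc23)N1c1ccccc1`: 44 nM
- compound 2 `CCN1C(=O)CS/C1=N/Nc1nncc2ccccc12`: 55 nM
- compound 3 `S=C(NNc1nncc2ccccc12)Nc1ccccc1`: 6 nM

Compound 2 shares the upper end of these numbers with compound 1, the two lying within the scatter of each other, while compound 3 lies lower, beyond the scatter. Compound 4 `O=C1CS/C(=N/Nc2nncc3ccccc23)N1` awaits measurement. It differs from compound 2 as follows: hydrogen in place of ethyl on an amide-type nitrogen in a ring. Going by the values given here, the one measured step at that nitrogen is a 1.3-fold higher number from compound 1 to compound 2 (0.10 log units; within the scatter), with ethyl in place of phenyl. Among the compounds with values here, with only that step as a guide, no move beyond the scatter is expected in this assay, and the estimated change is a 1.1-fold higher number from compound 2 to compound 4 (0.04 log units; within the scatter). Compound 4 is expected at 60 nM, within an estimated range of 20 nM to 180 nM.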

Compound 4, half-maximal inhibitory concentration: 46 nM
The estimate for compound 4 lay 1.3-fold (0.12 log units) above the measured number; measured number inside the range.
By their numbers in this assay, from the lowest: compound 3; then compounds 1, 4 and 2 (each within the scatter of the next).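

Hydrogen in place of ethyl on this amide-type nitrogen in a ring gives no move beyond the scatter in this assay (a 1.2-fold lower number from compound 2 to compound 4 (0.08 log units; within the scatter)), and hydrogen in place of phenyl gives none either (a 1.0-fold higher number from compound 1 to compound 4 (0.02 log units; within the scatter)). Hydrogen, ethyl and phenyl at this nitrogen therefore cannot be told apart in this read-out, so the nitrogen needs no carbon group for these numbers to hold. Nothing available accounts for this result.

Going by these compounds, whether a longer chain ending in an amine or a carboxylic acid at this nitrogen would keep the number within the scatter remains open. So does whether the carbonyl of the ring tolerates any change.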